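Bromo for chloro in a level pair

The compounds below may be only part of what the source reports. "The series", "measured", "known", "first", "only" and "open" are said of these compounds alone.

Within the data shown here, in a functional assay on DU-145 cells (Homo sapiens) for inhibition, read by trypan blue exclusion, with a stated time of 96 h (a lower number here means a stronger inhibitor of growth, a higher number a weaker inhibitor of growth), compound 1 `Cc1ccc(S/C(=C/c2c[nH]c3ccc(Br)cc23)C(=O)c2ccc(Br)cc2)cc1` gives 1000 nM and compound 2 `Cc1ccc(S/C(=C/c2c[nH]c3ccc(Cl)cc23)C(=O)c2ccc(Cl)cc2)cc1` stands level with it at 1000 nM on the numbers so far. Compound 3 `Cc1ccc(S/C(=C/c2c[nH]c3ccc(Br)cc23)C(=O)c2ccc(Cl)cc2)cc1` differs from compound 2 by a single swap (bromo in place of chloro on an aromatic carbon) with bromo in place of chloro on an aromatic carbon. Compound 1 already carries bromo there and gives 1000 nM so no step beyond the scatter is expected in this assay from this swap. The estimated change is no change at the digits printed from compound 2 to compound 3 (within the scatter) and no more than that is expected. Compound 3 is expected at 1000 nM (estimated range 500 nM to 2000 nM).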

Compound 3, concentration for 50% growth inhibition: 1000 nM
Estimate against measurement, compound 3: no gap at the digits printed; low and high end bracket the measured number.
By their numbers in this assay, from the lowest: compounds 1, 2 and 3 (each within the scatter of the next).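

Compound 1 and compound 2 differ in two places, so their level values could not show what either swap does alone. In this assay, bromo in place of chloro on the ring of the fused system gives no change at the digits printed from compound 2 to compound 3 (within the scatter), and chloro in place of bromo at the other halogen gives no change at the digits printed from compound 1 to compound 3 (within the scatter), so each swap has now been read singly. Nothing measured here explains why these halogens read alike.

On these data alone, whether an amine or a carboxylic acid at either place would read the same stays open.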